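Swapping the aryl amide ring: a chlorophenyl variant

A few compounds are considered here, and "the series" means these few. Any claim that something is new, unique, unknown or untested is made for them only; others in the source may bear on it.

Compound 1 `O=C(COc1ccc2cc(/C=C3/SC(=O)NC3=O)ccc2c1)Nc1ccc(Br)cc1F` belongs to a small set of closely related molecules that share one core and differ only in the aromatic ring attached to the amide nitrogen. In an assay on isolated protein for inhibition of histone deacetylase 4 (Homo sapiens), with a stated time of 1 h (on this read-out higher numbers stand for weaker inhibition and lower numbers for stronger inhibition), compound 1 gives 1900 nM. Compound 2 `COc1cccc(NC(=O)COc2ccc3cc(/C=C4/SC(=O)NC4=O)ccc3c2)c1` carries a 3-methoxyphenyl at that position, and in this assay compound 2 gives 1600 nM. Compound 3 `O=C(COc1ccc2cc(/C=C3/SC(=O)NC3=O)ccc2c1)Nc1cccc(C(F)(F)F)c1` carries a 3-(trifluoromethyl)phenyl there, and in this assay compound 3 gives 2500 nM. Among these numbers compound 1 stands second highest; its nearest neighbour is compound 2 and its furthest is compound 3, and neither gap is larger than the scatter.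

The unmeasured compound 4 `O=C(COc1ccc2cc(/C=C3/SC(=O)NC3=O)ccc2c1)Nc1cccc(Cl)c1` is reached from compound 1 by the change (3-chlorophenyl in place of 4-bromo-2-fluorophenyl on an amide-type nitrogen). For the measured compounds named here, two measured steps bear on this: a 1.2-fold lower number from compound 1 to compound 2 (0.07 log units; within the scatter) and a 1.3-fold higher number from compound 1 to compound 3 (0.12 log units; within the scatter). Both replace the same 4-bromo-2-fluorophenyl with a different aromatic ring, and both stayed within the scatter, as did a 1.6-fold higher number from compound 2 to compound 3 (0.19 log units; within the scatter). Every change of this ring so far has left this assay essentially unmoved, so for compound 4 no step beyond the scatter is expected in either direction, which is a 1.1-fold lower number from compound 1 to compound 4 (0.02 log units; within the scatter). The estimate for compound 4 in this assay is therefore 1800 nM, with a range from 900 nM to 3600 nM.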

Compound 4, half-maximal inhibitory concentration: 3800 nM
Compound 4: the middle estimate sits 2.1-fold (0.32 log units) below what was measured, and the stated range ends below it.
By their numbers in this assay, from the lowest: compounds 2, 1, 3 and 4 (each within the scatter of the next, the first and the last beyond it).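

For the compounds shown here, the aromatic ring on the amide-type nitrogen is not entirely silent in this assay: a 2.4-fold higher number from compound 2 to compound 4 (0.38 log units; beyond the scatter), the first step in this set to pass the scatter, and it comes from putting chloro in place of methoxy on an aromatic carbon. The effect is small and rests on this single pair, as a 2.0-fold higher number from compound 1 to compound 4 (0.30 log units; within the scatter) and a 1.5-fold higher number from compound 3 to compound 4 (0.18 log units; within the scatter), so compound 4 can be told apart from compound 2 but not from compound 1 or compound 3. Nothing available here explains why this one pair separates while the others do not.

From the compounds shown here alone, all four compounds carry a halogen, methoxy or trifluoromethyl group on an aromatic ring at this position, so it remains open whether this modest spread would hold or widen with an amine or a carboxylic acid on that ring. The same question stands for a cyclohexyl group in place of the aromatic ring, or for a longer chain joining the ring to the amide nitrogen.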